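Solubility notes: replacing the difluorophenyl sulfone

The compounds below may be only part of what the source reports. "The series", "measured", "known", "first", "only" and "open" are said of these compounds alone.

Compound 1 `O=C(NCc1ccc(S(=O)(=O)c2ccccc2)cc1)NCc1cccnc1` gives 10000 nM
Compound 2 `O=C(NCc1ccc(S(=O)(=O)c2cc(F)cc(F)c2)cc1)N1Cc2ccncc2C1` gives 16000 nM
Compound 3 `CC(=O)N1CCC(S(=O)(=O)c2ccc(CNC(=O)N3Cc4ccncc4C3)cc2)CC1` awaits measurement

In a physicochemical assay for solubility, in phosphate buffer, with a stated time of 24 h, at pH 7.4, tested at 100 uM (on this read-out higher numbers stand for higher solubility and lower numbers for lower solubility), compound 2 lies within the scatter of compound 1 and the two are not separated. The change to compound 3 is 1-acetylpiperidin-4-yl in place of 3,5-difluorophenyl on a sulfonyl sulfur with the rest of the structure kept as in compound 2. Within the data shown here, no measured pair shows this change, so any expectation here is tentative. In this assay the expected step of a 3.1-fold higher number from compound 2 to compound 3 (0.49 log units; beyond the scatter) is upward and beyond the scatter. Compound 3 is estimated at 50000 nM with an expected range of 18000 nM to 100000 nM as a working figure.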

Compound 3, solubility: 187000 nM
Compound 3: middle estimate off by 3.7-fold (0.57 log units), on the low side, and the stated range ends below it.
By their numbers in this assay, from the lowest: compounds 1 and 2 (each within the scatter of the next); then compound 3.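

In this assay, 1-acetylpiperidin-4-yl in place of 3,5-difluorophenyl on a sulfonyl sulfur gives a 12-fold higher number from compound 2 to compound 3 (1.07 log units; beyond the scatter). Among these compounds, this is the first step read at this position, and it shows that a change on the sulfonyl sulfur alone, with the rest of compound 2 kept, can shift the read-out by a large margin. Nothing shown explains the step. On these data alone, the non-aromatic ring and the acetyl group enter together, so their shares remain open. An unsubstituted piperidin-4-yl or a cyclohexyl group on the sulfonyl sulfur would separate them.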